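Adding a Methyl to the Acid Analogue: A Small Expected Shift

The source may report more compounds than this note shows. Statements on the series, on what has been measured and on what is new or still open speak of the compounds shown alone.

Of the compounds shown here, two sharing one core have been tested. Compound 1, `CCc1ccc2nc(C(=O)Nc3c(F)cc(-c4cccc(F)c4)cc3F)c(C)c(O)c2c1`, and compound 2, `Cc1ccc2nc(C(=O)Nc3c(F)cc(-c4cccc(F)c4)cc3F)c(C)c(C(=O)O)c2c1`, were measured in a functional assay on A-375 cells (Homo sapiens) for antiproliferative activity, read by MTT assay, with a stated time of 24 h, tested at 3.7 ug/mL; a lower number here means a weaker effect, a higher number a stronger effect of the compound at the concentration tested. In this assay compound 1 gives 17.9%, and compound 2 gives 9.25%. For the measured compounds named here, these two numbers lie within the scatter of each other, so compound 2 stands on a par with compound 1 rather than apart from it; no single-place step between measured compounds is available to guide an expectation.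

Compound 3, `CCc1ccc2nc(C(=O)Nc3c(F)cc(-c4cccc(F)c4)cc3F)c(C)c(C(=O)O)c2c1`, differs from compound 2 by methyl in place of hydrogen on a saturated chain carbon bound to an aromatic carbon. Going by the values given here, with no measured step of this kind to draw on, the change from compound 2 to compound 3 is expected to be small, with no direction beyond the scatter: a number 2.8 percentage points higher from compound 2 to compound 3 (within the scatter). Compound 3 is therefore estimated at 12%, in a range from 3% to 25%.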

Compound 3, a percentage reported as inhibition, at one concentration (the size of the read-out at that concentration, not a potency): 26.7%
Beside the measured number, compound 3's estimate is 14.7 percentage points below it; the whole stated range lies below it.
By their numbers in this assay, from the lowest: compounds 2, 1 and 3 (each within the scatter of the next, the first and the last beyond it).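

In this assay, methyl in place of hydrogen on a saturated chain carbon bound to an aromatic carbon gives a number 17.5 percentage points higher from compound 2 to compound 3 (beyond the scatter) and thus shows that this position responds to the addition of a single carbon atom, at least with the carboxy group present. With the ethyl group held constant, carboxy in place of hydroxy on an aromatic carbon gives a number 8.8 percentage points higher from compound 1 to compound 3 (within the scatter) and so separates the two groups no more than the usual scatter does. Nothing at hand explains why the added methyl matters.

Going by these compounds, whether the trend continues to a longer chain such as propyl, or to a branched one such as isopropyl, remains open. So does the outcome with an amine on the aromatic carbon that holds the carboxy group.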